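Truncating the benzyl ether of compound 2 to an isopropyl ether

A few compounds are considered here, and "the series" means these few. Any claim that something is new, unique, unknown or untested is made for them only; others in the source may bear on it.

Measured so far:
Compound 1, `O=C1CC(c2ccccc2OCc2ccc(F)cc2)Oc2ccccc21`: in a functional assay on J774.A1 cells (Mus musculus) for inhibition, read by immunoassay, with a stated time of 12 h, tested at 30 uM (a higher number here means more inhibition at the concentration tested (going by the name of the read-out), a lower number less inhibition), compound 1 gives 42.1%.
Compound 2, `CC(C)c1ccc(COc2ccccc2C2CC(=O)c3ccccc3O2)cc1`: in this assay compound 2 gives 91.7%.

Going by the values given here, compound 2 holds the higher of the two numbers, the only measured step being a number 49.6 percentage points higher from compound 1 to compound 2 (beyond the scatter), a large change beyond the scatter. Compound 3, `CC(C)COc1ccccc1C1CC(=O)c2ccccc2O1`, is the next member: isopropyl in place of 4-isopropylphenyl on a saturated chain carbon bound to an oxygen on an aromatic ring. Among the compounds with values here, no measured step covers the loss of the aromatic ring itself; the one step known swaps a substituent on that ring, so it bears only loosely on this change. Since the large gain in this assay accompanied the isopropyl-bearing ring that is now removed, the expectation is a drop, though an isopropyl group remains in compound 3. Compound 3 is therefore expected to give 55% in this assay, within 25% to 85%, a step of a number 36.7 percentage points lower from compound 2 to compound 3 (beyond the scatter).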

Compound 3, a percentage reported as inhibition, at one concentration (the size of the read-out at that concentration, not a potency): 33.5%
Compound 3: middle estimate off by 21.5 percentage points, on the high side; the measured number falls inside the stated range.
By their numbers in this assay, from the lowest: compounds 3 and 1 (each within the scatter of the next); then compound 2.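

At the place on a saturated chain carbon bound to an oxygen on an aromatic ring, the high number in this assay depends on more than the shared core, as isopropyl in place of 4-isopropylphenyl gives a large step (a number 58.2 percentage points lower from compound 2 to compound 3 (beyond the scatter)). Isopropyl in place of 4-fluorophenyl stays within the scatter (a number 8.6 percentage points lower from compound 1 to compound 3 (within the scatter)), so an aromatic ring at this place does not by itself give a high number, and an isopropyl group gives one only in compound 2, where it sits on that ring. No available evidence bears on the reason for either step.

Open, going by these compounds, is whether an unsubstituted phenyl ring or a longer chain such as n-hexyl at this place would read close to compound 2 or compound 3. Also open, on these data alone, is how a tert-butyl group, an amine or a carboxylic acid on the ring would compare with the isopropyl group of compound 2.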